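The source may hold more compounds than are shown below. What is called first, only, known or untested is meant among the compounds shown, and "the series" means these compounds.

Compound 2 `O=C(/C=C/c1cccc([N+](=O)[O-])c1)c1ccc(NC(=O)c2cccs2)cc1` gives the lower of the two numbers measured in a functional assay on DLD-1 cells (Homo sapiens) for cytotoxicity, read by resazurin assay, with a stated time of 48 h (on this read-out lower numbers stand for an effect already at smaller amounts and higher numbers for an effect only at larger amounts of compound), at 11000 nM. Among the compounds with values here, compound 1 `O=C(/C=C/c1ccco1)c1ccc(NC(=O)c2ccccc2)cc1`, the only other measured compound, gives 69000 nM in this assay, a higher number and a gap beyond the scatter. Compound 3 `O=C(/C=C/c1cccc([N+](=O)[O-])c1)c1ccc(NC(=O)c2ccccc2)cc1` differs from compound 2 in one place: phenyl in place of thiophen-2-yl on a carbonyl carbon. Within the data shown here, no pair of measured compounds shows this change on its own, so its effect is not known here. The step of a 1.5-fold higher number from compound 2 to compound 3 (0.16 log units; within the scatter) is expected to be small, toward a somewhat higher number, close to the scatter. Compound 3 is therefore estimated at 16000 nM, with a range from 5000 nM to 50000 nM.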

Compound 3, half-maximal effective concentration: > 100000 nM
Compound 3: only a limit was reported; the forecaster's own chance of this, stated with the estimate: 5%; at least 6.2-fold (0.79 log units) between middle value and limit.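

Compound 3 reaches a limit of the assay, not a number: the limit of > 100000 nM in this assay, at which 1 of the 3 values shown sits. In this assay, phenyl in place of thiophen-2-yl on this carbonyl carbon gives an at least 9.0-fold higher number from compound 2 to compound 3 (0.95 log units; beyond the scatter), so this position responds to the change of ring. The other step, an at least 1.4-fold higher number from compound 1 to compound 3 (0.16 log units; that floor lies within the scatter), does not separate the two compounds, since its floor lies within the scatter.

Going by these compounds, how far compound 3 lies past its limit stays open. So does whether a pyridin-2-yl ring or a furan-2-yl ring on this carbonyl carbon would behave like thiophen-2-yl.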